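Swapping the acid side chain on compound 2

The compounds below may be only part of what the source reports. "The series", "measured", "known", "first", "only" and "open" are said of these compounds alone.

Measured so far in an assay on cell membranes for inhibition of thromboxane A2 receptor (Homo sapiens); a lower number here means tighter binding, a higher number weaker binding:
compound 1 `O=C(O)Cc1cccc(CC2C3CCC(O3)C2/C=N/NC(=O)Nc2ccccc2)c1` gives 171 nM
compound 2 `O=C(O)COc1ccccc1CC1C2CCC(O2)C1/C=N/NC(=O)Nc1ccccc1` gives 6 nM

Compound 2 has the lower of the two numbers; compound 1 lies well above it, beyond the scatter. Compound 3 `O=C(O)CCCc1ccccc1CC1C2CCC(O2)C1/C=N/NC(=O)Nc1ccccc1` keeps the rest of compound 2 and alters one group: 3-carboxypropyl in place of carboxymethoxy on an aromatic carbon. Among the compounds with values here, no measured pair shows this exact swap, so the step in this assay has no close precedent, and only a moderate weakening is expected, a 3.3-fold higher number from compound 2 to compound 3 (0.52 log units; beyond the scatter). Compound 3 is therefore estimated at 20 nM, expected to fall between 4 nM and 100 nM.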

Compound 3, dissociation constant: 21.1 nM
Estimate against measurement, compound 3: 1.1-fold (0.02 log units) below; the range from low to high includes it.
By their numbers in this assay, from the lowest: compound 2; then compound 3; then compound 1.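

In this assay, putting 3-carboxypropyl in place of carboxymethoxy on this aromatic carbon, ortho to a large group, gives a 3.5-fold higher number from compound 2 to compound 3 (0.55 log units; beyond the scatter), so the oxygen of carboxymethoxy helps but binding does not depend on it. The entering group is also larger, with 6 heavy atoms against 5, so the loss of that oxygen and the change in size cannot be told apart. Nothing measured here explains the step. Still open, as far as these compounds go, is whether the shorter 2-carboxyethyl chain would behave like either group, and whether an amide or a tetrazole could replace the carboxylic acid at this position.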